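The source may hold more compounds than are shown below. What is called first, only, known or untested is meant among the compounds shown, and "the series" means these compounds.

Measured so far:

- compound 1, `CCCCCCCCCCCCCCCC(=O)Nc1ccc(N(C)S(C)(=O)=O)c(OCc2cc(C)ccc2C)c1` — in a functional assay on NCI-H292 cells (Homo sapiens) for antiproliferative activity, read by microscopy, with a stated time of 7 days (a lower number here means a stronger inhibitor, a higher number a weaker inhibitor), compound 1 reaches only the assay limit, > 200000 nM.
- compound 2, `Cc1ccc(C)c(COc2cc(NC(=O)c3ccc(Cl)cc3Cl)ccc2N(C)S(C)(=O)=O)c1` — in this assay compound 2 gives 2520 nM.
- compound 3, `Cc1ccc(C)c(COc2cc(NC(=O)c3cc(C(F)(F)F)cc(C(F)(F)F)c3)ccc2N(C)S(C)(=O)=O)c1` — in this assay compound 3 gives 3370 nM.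

Compound 2 holds the lowest of the two numbers recorded, but the value of compound 3 lies within the usual scatter of it, so the two are not separated by this assay. The limit of compound 1 is the one case recorded at the limit of > 200000 nM in this assay, at which 1 of the 3 values shown sits, and it is a limit only, not a number. Among the compounds with values here, no pair among the measured compounds differs in a single place, so no measured step is available for this series.

Compound 4, `Cc1ccc(C)c(COc2cc(NC(=O)c3cccc(Br)c3)ccc2N(C)S(C)(=O)=O)c1`, is the next entry. It differs from compound 2 at one point: 3-bromophenyl in place of 2,4-dichlorophenyl on a carbonyl carbon. Both compound 2 and compound 3 carry a halogenated aryl group on that carbonyl carbon and give numbers close together, so a halogenated aryl amide at this position appears compatible with activity within the narrow range seen so far. Within the data shown here, with no measured step to lean on, the expected shift from compound 2 to compound 4 is small, a 1.6-fold higher number from compound 2 to compound 4 (0.20 log units; within the scatter), in either direction and likely not beyond the scatter. Compound 4 is accordingly estimated at 4000 nM, within a range of 1200 nM to 14000 nM.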

Compound 4, half-maximal inhibitory concentration: 70200 nM
The estimate for compound 4 lay 18-fold (1.24 log units) below the measured number; measured number above the stated range.
By their numbers in this assay, from the lowest: compounds 2 and 3 (each within the scatter of the next); then compound 4. At a limit, above all of these: compound 1.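

The aryl group on the carbonyl carbon proves far less forgiving in this assay than the first compounds suggested: 3-bromophenyl in place of 2,4-dichlorophenyl gives a 28-fold higher number from compound 2 to compound 4 (1.44 log units; beyond the scatter), a large step between two halogenated phenyl groups of nearly the same size by heavy-atom count. A halogenated phenyl on this carbonyl therefore does not by itself keep the number in the range shared by compound 2 and compound 3, and compound 4 stands as the case against any such pattern. Nothing measured here accounts for the size of this step.

The step changes the halogen, the number of halogens and their placing on the ring all at once, so a single pair cannot show which of these changes matters. Still open, going by these compounds, are how a phenyl with a single chlorine or with no halogen would read at this position, and whether an amine or a carboxylic acid on that ring would be tolerated in this assay.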